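Benzofuran for Phenyl: Expected Cytotoxicity of Compound 4

The compounds below may be only part of what the source reports. "The series", "measured", "known", "first", "only" and "open" are said of these compounds alone.

The measured compounds, all in a toxicity assay on NIH3T3 cells (Mus musculus) for cytotoxicity, read by resazurin assay; on this read-out lower numbers stand for an effect already at smaller amounts and higher numbers for an effect only at larger amounts of compound:
Compound 1 `c1ccc(-c2ccc(Cn3cncc3CNc3ccc(-c4ccc[nH]4)c(-c4ccccc4)c3)cc2)cc1` gives > 10000 nM, which is a limit of the assay and not a number.
Compound 2 `COC(=O)c1ccc(NCc2cncn2Cc2ccc(-c3ccccc3)cc2)cc1-c1ccccc1` gives > 1000 nM, also a limit of the assay.
Compound 3 `c1ccc(-c2ccc(Cn3cncc3CNc3ccc(-c4ccccc4)c(-c4ccccc4)c3)cc2)cc1` gives > 10000 nM, again a limit of the assay.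

Compound 3 thus stands at a limit only, and the two further values shown are limits as well: the limit of > 10000 nM in this assay, at which 2 of the 3 values shown sit, and (the limit of > 1000 nM in this assay, at which 1 of the 3 values shown sits). The three single-point changes among the measured compounds carry no readable size: a step that the two limits leave unreadable from compound 1 to compound 2, a step that the two limits leave unreadable from compound 1 to compound 3 and a step that the two limits leave unreadable from compound 2 to compound 3. None of them tells how a change on this aromatic carbon moves the read-out in this assay.

Compound 4 `c1ccc(-c2ccc(Cn3cncc3CNc3ccc(-c4cc5ccccc5o4)c(-c4ccccc4)c3)cc2)cc1` differs from compound 3 in one place: 1-benzofuran-2-yl in place of phenyl on an aromatic carbon. The bearing steps are those at the same aromatic carbon, from compound 1 to compound 2 and to compound 3 and from compound 2 to compound 3, and all of them are unreadable, so no step beyond the scatter can be foreseen in this assay. The step from compound 3 to compound 4 is therefore expected to be close to none, as a step that the limit leaves unreadable from compound 3 to compound 4. Compound 4 is expected to give about 15000 nM in this assay, within a range from 4000 nM to 60000 nM, most likely reported again only as a limit.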

Compound 4, half-maximal effective concentration: > 10000 nM
Compound 4: only a limit was reported (the forecaster's own chance of this, stated with the estimate: 75%); the middle value lies beyond the limit too.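

In this assay compound 4 gives > 10000 nM, which is a limit of the assay and not a number. Within the data shown here, the steps to compound 4 from compound 1, compound 2 and compound 3 cannot be read, so no new step emerges. The compounds shown leave open whether the groups on this aromatic carbon differ in cytotoxicity at all.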